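The source may report more compounds than this note shows. Statements on the series, on what has been measured and on what is new or still open speak of the compounds shown alone.

Measured so far in an ADME assay (liver) for metabolic stability, with Liver microsome (Rattus norvegicus) as the target, using microsomes and NADPH, with a stated time of 30 min, tested at 1 uM; a lower number here means slower removal, a higher number faster removal of the compound:
- compound 1 `Nc1ccc(S(=O)(=O)N2CCN(c3ncc(C(O)(C(F)(F)F)C(F)(F)F)cc3C#CCO)CC2)cn1` gives 65 mL.min-1.g-1
- compound 2 `COCC#Cc1cc(C(O)(C(F)(F)F)C(F)(F)F)cnc1N1CCN(S(=O)(=O)c2ccc(N)nc2)CC1` gives 399 mL.min-1.g-1

Of these two numbers, compound 2 holds the higher, with 399 mL.min-1.g-1, which places it at the fast-removal end of this small set. The next compound, compound 3 `Cn1cc(-c2cc(C(O)(C(F)(F)F)C(F)(F)F)cnc2N2CCN(S(=O)(=O)c3ccc(N)nc3)CC2)cn1`, has not yet been measured in this assay. It departs from compound 2 in one place: 1-methyl-1H-pyrazol-4-yl stands in place of 3-methoxyprop-1-yn-1-yl on an aromatic carbon, (1-methyl-1H-pyrazol-4-yl in place of 3-methoxyprop-1-yn-1-yl on an aromatic carbon).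

Among the measured compounds shown here, only one measured step bears on this change, and only indirectly. That step is a 6.1-fold higher number from compound 1 to compound 2 (0.79 log units; beyond the scatter), and it arose from methyl in place of hydrogen on an oxygen on a saturated carbon, within the very group that now leaves. It shows that the number responds strongly to changes in this group. For the measured compounds named here, no measured compound carries the entering group, so the direction is an expectation with little support. A lower number is expected, by a step smaller than the measured one. The expected change is a 2.7-fold lower number from compound 2 to compound 3 (0.42 log units; beyond the scatter). Compound 3 is estimated at 150 mL.min-1.g-1, with an expected range from 50 mL.min-1.g-1 to 420 mL.min-1.g-1.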

Compound 3, intrinsic clearance in microsomes: 44 mL.min-1.g-1
Beside the measured number, compound 3's estimate is 3.4-fold (0.53 log units) above it; measured number below the stated range.
By their numbers in this assay, from the lowest: compounds 3 and 1 (each within the scatter of the next); then compound 2.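

In this assay, the aromatic carbon ortho to a large group turns out to carry a five-membered aromatic ring as well as a chain, and a 9.1-fold lower number from compound 2 to compound 3 (0.96 log units; beyond the scatter) shows that the 1-methyl-1H-pyrazol-4-yl group removes the high number seen with 3-methoxyprop-1-yn-1-yl. Set against the free alcohol chain, the same ring gives a 1.5-fold lower number from compound 1 to compound 3 (0.17 log units; within the scatter) in this assay, so of the three compounds shown only compound 2, with its methyl ether chain, stands apart, and a methyl group alone does not go with the high number, since compound 3 carries one on its ring. No measurement available here explains why these groups differ and the numbers therefore describe the change without accounting for it.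

The compounds shown leave open whether the low number belongs to the pyrazole ring itself or simply follows from the loss of the methyl ether and the triple bond. A pyrazole without its methyl, a phenyl ring or a saturated methoxypropyl chain on the same carbon would be needed to separate these readings.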